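The source may report more compounds than this note shows. Statements on the series, on what has been measured and on what is new or still open speak of the compounds shown alone.

Of the compounds shown here, three have been measured in a functional assay on HepG2 cells (Homo sapiens) for cytotoxicity, read by MTT assay, with a stated time of 24 h; on this read-out lower numbers stand for stronger inhibition and higher numbers for weaker inhibition. Compound 1, `COc1cc(O)cc(/C=C/c2ccc(O)c(OC)c2OC)c1`, gives 37100 nM. Compound 3, `COc1cc(O)cc(/C=C/c2cccc(O)c2OC)c1`, gives 90800 nM. Compound 2, `COc1cc(O)cc(/C=C/c2cccc(O)c2O)c1`, reaches only the limit of the assay, > 100000 nM, and no number is known for it. Among the two numbers shown, compound 3 stands highest; its nearest neighbour is compound 1, whose number is lower by a gap beyond the usual scatter. Compound 4, `COc1c(O)cccc1/C=C/c1cc(O)cc(O)c1`, has not yet been measured. It differs from compound 3 in one place: hydrogen in place of methyl on an oxygen on an aromatic ring. Among the compounds with values here, one measured step bears on this change, though at a different oxygen and in the opposite direction: an at least 1.1-fold lower number from compound 2 to compound 3 (0.04 log units; that floor lies within the scatter), a size that rests on the limit of > 100000 nM in this assay, at which 1 of the 3 values shown sits, and does not leave the scatter. On that evidence the removal of a methyl from an aromatic oxygen is expected to move the number little, if at all, and the change is therefore estimated to give a 1.0-fold lower number from compound 3 to compound 4 (0.00 log units; within the scatter). Compound 4 is accordingly expected to give about 90000 nM in this assay, with a range from 40000 nM to 200000 nM, and a fair chance that the assay again reports only a limit.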

Compound 4, half-maximal inhibitory concentration: > 100000 nM
Compound 4 gave a limit, no number (the forecaster's own chance of this, stated with the estimate: 35%); at least 1.1-fold (0.04 log units) between middle value and limit.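

In this assay compound 4 gives > 100000 nM, and this is a limit of the assay, not a number. The earlier compounds shown here had tested a methyl on a different oxygen, and the present result adds that methoxy to hydroxy at this oxygen also ends at that limit, with an at least 1.1-fold higher number from compound 3 to compound 4 (0.04 log units; that floor lies within the scatter) as the only size that can be stated. So among the compounds shown, the two that carry a hydroxy in place of one of the methoxy groups of compound 3, namely compound 2 and compound 4, both sit at the limit, but how far either lies from compound 3 cannot be read, because each step rests on that limit: the limit of > 100000 nM in this assay, at which 2 of the 4 values shown sit.

The compounds shown leave open whether removing the methyl at this oxygen moves the read-out beyond the usual scatter or hardly at all. They also leave open what a longer chain on this oxygen, such as ethyl, or an amine in place of the methoxy would do in this assay, and whether either would return a number instead of a limit.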